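The source may hold more compounds than are shown below. What is called first, only, known or untested is meant among the compounds shown, and "the series" means these compounds.

In a functional assay for inhibition, with Rattus norvegicus as the target (a lower number here means a stronger inhibitor, a higher number a weaker inhibitor), compound 1 (`CC(/N=c1\c(O)c(O)\c1=N/c1cccnc1)C(C)(C)C`) gives 1950 nM and compound 2 (`CC(/N=c1\c(O)c(O)\c1=N/c1cncc(Br)c1)C(C)(C)C`) gives 11700 nM, so compound 2 holds the higher of the two numeric values. Compound 3 (`CC(/N=c1\c(O)c(O)\c1=N/c1cnc2ccccc2c1)C(C)(C)C`) is reported as > 30000 nM, which is a limit of the assay and not a number.

Compound 4 (`CC(/N=c1\c(O)c(O)\c1=N/c1ccc(Br)cc1)C(C)(C)C`) has not yet been measured. It carries 4-bromophenyl in place of 5-bromopyridin-3-yl on a double-bonded nitrogen. Within the data shown here, the only measured step that bears on this change is a 6.0-fold higher number from compound 1 to compound 2 (0.78 log units; beyond the scatter), a modest step made by placing bromo on an aromatic carbon. Among the measured compounds shown here, no measured step replaces a pyridinyl ring with a phenyl ring, so that step guides the expected size only loosely. A modest move toward a lower number is expected, given that compound 1, which lacks the bromo, stands at 1950 nM. The expected change is a 2.3-fold lower number from compound 2 to compound 4 (0.37 log units; beyond the scatter). For compound 4 the estimated value is 5000 nM, with an expected range of 1000 nM to 25000 nM.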

Compound 4, half-maximal inhibitory concentration: 1260 nM
Compound 4: middle estimate off by 4.0-fold (0.60 log units), on the high side; the measured number falls inside the stated range.
By their numbers in this assay, from the lowest: compounds 4 and 1 (each within the scatter of the next); then compound 2. At a limit, above all of these: compound 3.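

In this assay, the step of a 9.3-fold lower number from compound 2 to compound 4 (0.97 log units; beyond the scatter) shows that a bromo-bearing ring on the double-bonded nitrogen need not carry the cost seen in the step of a 6.0-fold higher number from compound 1 to compound 2 (0.78 log units; beyond the scatter) on the pyridine series. Pyridin-3-yl and 4-bromophenyl at this place are not separated by the step of a 1.5-fold lower number from compound 1 to compound 4 (0.19 log units; within the scatter) in this assay, so a bromo group and a ring of carbon only can together match the unsubstituted pyridin-3-yl group. Nothing measured here accounts for these steps.

The swap removes the ring nitrogen and also moves the bromo, so the compounds shown leave open which of the two carries the step. They also leave open how a plain phenyl group, or a phenyl group bearing an amine or a carboxylic acid in place of bromo, would read here.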